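This account rests on a few compounds, and the source may have more. Where it says the series, first, only, none or still open, it means among the compounds named here.

Compound 1 `O=C(O)[C@@H]1CCCN1C(=O)CN(c1nc(Cl)nc2[nH]cnc12)C1CC1` gives 31.5%.
Compound 2 `O=C(CN(c1ncnc2c1ncn2C1CCCCO1)C1CC1)N[C@@H](CO)C(=O)OCc1ccccc1` gives 27.8%.
Compound 3 `CSCC[C@H](NC(=O)CN(c1nc(Cl)nc2[nH]cnc12)C1CC1)C(=O)OCc1ccccc1` gives 22.2%.

These three values come from a functional assay on the whole organism (Tail, strain ICR) with Mus musculus as the target, in the tail flick test, with a stated time of 30 min, at a dose of 25 umol/kg by the oral route; on this read-out higher numbers stand for a stronger effect at the one dose given and lower numbers for a weaker effect. In this assay compound 3 returns the smallest of the three numbers, yet compound 2 and compound 1 both lie within the usual scatter of it, so the three cannot be told apart on these data. The next compound, compound 4 `O=C(CN(c1nc(Cl)nc2[nH]cnc12)C1CC1)N[C@@H](CC(=O)OCc1ccccc1)C(=O)OCc1ccccc1`, has not been measured. It differs from compound 3 in one place: benzyloxycarbonyl in place of (methylsulfanyl)methyl on a saturated chain carbon, two bonds along the chain from an amide-type nitrogen and a carbonyl carbon. Going by the values given here, no step between two measured compounds shows what such a change does, so the expected step from compound 3 to compound 4 is none beyond the scatter, a number 2.8 percentage points higher from compound 3 to compound 4 (within the scatter), in either direction. Compound 4 is therefore expected to give 25%, within a range from 12% to 40%.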

Compound 4, a percentage reported as activity, at one dose (the size of the read-out at that dose, not a potency): 34.7%
For compound 4 the middle estimate is 9.7 percentage points below the measured one, and the stated range covers the measured number.
By their numbers in this assay, from the lowest: compounds 3, 2, 1 and 4 (each within the scatter of the next, the first and the last beyond it).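

In this assay, going by these compounds alone, benzyloxycarbonyl in place of (methylsulfanyl)methyl gives a number 12.5 percentage points higher from compound 3 to compound 4 (beyond the scatter) and is the only step in the set that can be read. It shows that the saturated chain carbon, two bonds along the chain from an amide-type nitrogen and a carbonyl carbon, tolerates a group with a six-membered aromatic ring with no loss of effect at this one dose. No evidence here gives a cause for this step. Going by these compounds, whether the ester or the aromatic ring carries the step stays open, and a carboxylic acid or a plain benzyl group on this carbon would separate the two.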